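Benzothiazolyl Hydrazones on HL-60 Cells: Bromine Gives Way to Pyridyl

The compounds below may be only part of what the source reports. "The series", "measured", "known", "first", "only" and "open" are said of these compounds alone.

Compound 1 `Clc1ccc(/C=N/Nc2nc3ccccc3s2)cc1`: > 17300 nM, a limit of the assay.
Compound 2 `Brc1ccc(/C=N/Nc2nc3ccccc3s2)cc1`: > 15000 nM, also a limit.

In a functional assay on HL-60 cells (Homo sapiens) for cytotoxicity, read by MTT assay, with a stated time of 72 h (a lower number here means a stronger inhibitor, a higher number a weaker inhibitor), compound 1 gives only a limit, > 17300 nM. Compound 2 likewise gives only a limit, > 15000 nM. The step that the two limits leave unreadable from compound 1 to compound 2 therefore stays unreadable, since both values sit at limits the limit of > 17300 nM in this assay, at which 1 of the 2 values shown sits (the limit of > 15000 nM in this assay, at which 1 of the 2 values shown sits).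

Compound 3 `C(=N/Nc1nc2ccccc2s1)\c1ccc(-c2ccccn2)cc1` differs from compound 2 by pyridin-2-yl in place of bromo on an aromatic carbon. Going by the values given here, no measured step covers such a change, and the single step in hand has no readable size. Compound 3 is therefore expected to sit near 15000 nM, in a range from 3000 nM to 60000 nM, most probably again as a limit. The step of a number no higher from compound 2 to compound 3 (the limit leaves the size open) is estimated to stay within the scatter, in no clear direction.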

Compound 3, half-maximal inhibitory concentration: 11500 nM
For compound 3 the middle estimate is 1.3-fold (0.12 log units) above the measured one; the range from low to high includes it.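

In this assay, going by these compounds alone, pyridin-2-yl on this aromatic carbon, para to a large group, gives the only value shown that is not a limit, with an at least 1.3-fold lower number from compound 2 to compound 3 (0.11 log units; that floor lies within the scatter) and an at least 1.5-fold lower number from compound 1 to compound 3 (0.17 log units; that floor lies within the scatter). On these data alone, the size of the first step stays open, as compound 2 gives only a limit: the limit of > 15000 nM in this assay, at which 1 of the 3 values shown sits. The size of the second stays open too, as compound 1 also gives only a limit: the limit of > 17300 nM in this assay, at which 1 of the 3 values shown sits.

Left open is whether a plain phenyl ring in this place would read like compound 3, and so whether the ring nitrogen matters. As far as these compounds go, how an amine or a carboxylic acid here would read also remains open.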